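Swapping the aryl on the triazole of a weak antiproliferative core

This account rests on a few compounds, and the source may have more. Where it says the series, first, only, none or still open, it means among the compounds named here.

For the measured compounds named here, compound 2 `COc1ccc(OC)c(-n2nncc2CN2C(=O)C3(C(C#N)=C(N)Oc4c(N)cc5nc6ccccc6nc5c43)c3ccccc32)c1` holds the only number given: in a functional assay on HepG2 cells (Homo sapiens) for antiproliferative activity, read by MTT assay, with a stated time of 48 h (on this read-out lower numbers stand for stronger inhibition and higher numbers for weaker inhibition), compound 2 gives 45100 nM. Compound 1 `Cc1cc(C)cc(-n2nncc2CN2C(=O)C3(C(C#N)=C(N)Oc4c(N)cc5nc6ccccc6nc5c43)c3ccccc32)c1` reaches only a limit in this assay, > 50000 nM. Going by the values given here, the one measured step, an at least 1.1-fold lower number from compound 1 to compound 2 (0.04 log units; that floor lies within the scatter), is within the scatter. Compound 3 `N#CC1=C(N)Oc2c(N)cc3nc4ccccc4nc3c2C12C(=O)N(Cc1cnnn1-c1ccc(F)c(Cl)c1)c1ccccc12` carries 3-chloro-4-fluorophenyl in place of 2,5-dimethoxyphenyl on an aromatic nitrogen. Among the compounds with values here, no measured step concerns a halogenated aryl here, so no shift beyond the scatter is expected, and a limit remains possible given (the limit of > 50000 nM in this assay, at which 1 of the 2 values shown sits). Compound 3 is therefore estimated at 40000 nM, between 12000 nM and 120000 nM, which means an expected step of a 1.1-fold lower number from compound 2 to compound 3 (0.05 log units; within the scatter).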

Compound 3, half-maximal inhibitory concentration: > 50000 nM
Compound 3: only a limit was reported; the forecaster's own chance of this, stated with the estimate: 40%; middle value at least 1.2-fold (0.09 log units) from the limit.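

In this assay compound 3 reaches only a limit of > 50000 nM. The first halogenated aryl shown on this aromatic nitrogen, 3-chloro-4-fluorophenyl in place of 2,5-dimethoxyphenyl, gives an at least 1.1-fold higher number from compound 2 to compound 3 (0.04 log units; that floor lies within the scatter) and the step from compound 1 cannot be read, since both of its values are limits. The values shown now gather at one limit: the limit of > 50000 nM in this assay, at which 2 of the 3 values shown sit. From the compounds shown here alone, whether any group at this position can bring a number clearly lower stays open. An aryl carrying an amine or a carboxylic acid, or a longer chain in place of the aryl, would test this.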